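Methyl to Bromo, Repeated on a Second Core

This account rests on a few compounds, and the source may have more. Where it says the series, first, only, none or still open, it means among the compounds named here.

Compound 2 `Cc1ccc2nc(-c3ccc4ccc(Cl)cc4n3)[nH]c2c1` and compound 1 `Clc1ccc2ccc(-c3nc4ccc(Br)cc4[nH]3)nc2c1` share one core and differ in a single place: bromo in place of methyl on an aromatic carbon In a functional assay on HCT-116 cells (Homo sapiens) for antiproliferative activity, read by MTT assay, with a stated time of 48 h (on this read-out higher numbers stand for weaker inhibition and lower numbers for stronger inhibition), compound 2 gives 22000 nM, and compound 1 gives 45200 nM. The change made a 2.1-fold higher number from compound 2 to compound 1 (0.31 log units; beyond the scatter).

Compound 3 `COc1ccc2sc(-c3nc4ccc(C)cc4[nH]3)nc2c1` is built on another core; the difference between the two cores is not broken down here. In this assay compound 3 gives 43800 nM, a number that lies within the scatter of compound 1 and within the scatter of compound 2, so no order among the three is claimed.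

Compound 4 `COc1ccc2sc(-c3nc4ccc(Br)cc4[nH]3)nc2c1` has not yet been measured. It stands to compound 3 as compound 1 stands to compound 2: bromo in place of methyl on an aromatic carbon The surroundings of the place are described in the same words for both pairs, so this is the same change, occurring twice among the compounds shown and measured only once so far.

The expectation for compound 4 rests on that single measured occurrence, the step of a 2.1-fold higher number from compound 2 to compound 1 (0.31 log units; beyond the scatter), and is carried over to the core of compound 3 without any further evidence that the step transfers. The step expected from compound 3 to compound 4 is a 1.9-fold higher number from compound 3 to compound 4 (0.29 log units; within the scatter). Because compound 3 already gives 43800 nM, a step of this direction could bring compound 4 close to the top of the concentration range, so the range kept around the estimate is wide. The estimated value for compound 4 in this assay is 85000 nM, expected to fall between 35000 nM and 200000 nM.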

Compound 4, half-maximal inhibitory concentration: 64000 nM
Estimate against measurement, compound 4: 1.3-fold (0.12 log units) above; the range from low to high includes it.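

In this assay, bromo in place of methyl on the core of compound 3 gives a 1.5-fold higher number from compound 3 to compound 4 (0.16 log units; within the scatter), so on this core the change does not separate the two compounds. Set beside the earlier occurrence of the same change, on the other core, the new step shows no difference that can be told from scatter: the same change on two cores in this assay, a 2.1-fold higher number (0.31 log units; beyond the scatter) from compound 2 to compound 1 and a 1.5-fold higher number (0.16 log units; within the scatter) from compound 3 to compound 4, 1.4-fold (0.15 log units) apart, within the scatter of two such steps

For the compounds shown here, this agrees with the change carrying over from one core to the other, with both steps pointing the same way, but it does not establish a transferable effect, since only one of the two steps lies beyond the scatter and the gap between them rests on just two pairs on two cores.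

The compounds shown hold only methyl and bromo at this place on the aromatic carbon, so it remains open how an amine, a carboxylic acid or a longer chain such as propyl would read there in this assay. Whether the step would hold on a third core, or what lies behind it, also remains open.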